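The source may report more compounds than this note shows. Statements on the series, on what has been measured and on what is new or still open speak of the compounds shown alone.

Of the compounds shown here, three have been measured in a physicochemical assay for metabolic stability, read by LC-MS, in phosphate buffer, tested at 1 uM; a higher number here means that the compound lasts longer, a lower number that the compound disappears faster. Compound 1 `CC(=O)OCC1CN(S(=O)(=O)c2ccc(F)cc2)CCN1C(C)=O` carries an acetyl on an oxygen on a saturated carbon. In this assay compound 1 reaches the limit of the assay, >= 4 h, which is a limit and not a number. Compound 2 `CC(=O)OCC1CN(C(C)=O)CCN1S(=O)(=O)c1ccc(F)cc1` is built from the same atoms as compound 1, joined differently; the difference between the two cores is not broken down here. In this assay compound 2 also stops at the limit, >= 4 h. Compound 3 `COCC1CN(S(=O)(=O)c2ccc(F)cc2)CCN1C(C)=O` differs from compound 1 by methyl in place of acetyl on an oxygen on a saturated carbon. In this assay compound 3 likewise sits at the limit, >= 4 h. The step that the two limits leave unreadable from compound 1 to compound 3 cannot be sized, since the limit of >= 4 h in this assay, at which 3 of the 3 values shown sit, holds every value shown. Among the compounds with values here, compound 4 `COCC1CN(C(C)=O)CCN1S(=O)(=O)c1ccc(F)cc1` is still to be measured; it differs from compound 2 by methyl in place of acetyl on an oxygen on a saturated carbon, the same change at the same place as the one from compound 1 to compound 3. The expected step is a step that the limit leaves unreadable from compound 2 to compound 4, beside the unreadable earlier one, and it rests on (the limit of >= 4 h in this assay, at which 3 of the 3 values shown sit). Compound 4 is estimated at 6 h, with a range from 3 h to 14 h.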

Compound 4, half-life: >= 4 h
Compound 4 ended at the assay's limit; the forecaster's own chance of this, stated with the estimate: 85%; the middle value is on the limit's open side.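

No new step can be read between compound 2 and compound 4 in this assay, because both values are limits and not numbers: the limit of >= 4 h in this assay, at which 4 of the 4 values shown sit. The compounds shown leave open the actual half-life of each of the four, and so whether methyl in place of acetyl, or the difference between the two cores, changes it at all.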